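Replacing a Methyl Hydrogen in Compound 1 with Phenylsulfanyl

The source may report more compounds than this note shows. Statements on the series, on what has been measured and on what is new or still open speak of the compounds shown alone.

Measured compounds:
compound 1, `Cc1nc(-c2ccc(Cl)cc2)c(CC(=O)O)s1`: 50%
compound 2, `NS(=O)(=O)c1cccc(-c2nc(C(c3ccc(F)cc3)c3ccc(F)cc3)sc2CC(=O)O)c1`: 55%

In an in vitro functional assay on HEK285-7 cells for antagonist activity at prostaglandin D2 receptor 2 (Homo sapiens), read by BRET and beta-arrestin recruitment (on this read-out higher numbers stand for larger maximal responses and lower numbers for smaller maximal responses), compound 1 gives 50%, the lower of the two numbers in hand. Compound 2 gives 55%, a number only a few points away, so the two values sit within the usual scatter and show no order between them. Compound 3, `O=C(O)Cc1sc(CSc2ccccc2)nc1-c1ccc(Cl)cc1`, carries the change (phenylsulfanyl in place of hydrogen on a saturated chain carbon bound to an aromatic carbon); cut one bond further out, this reads as methyl becoming (phenylsulfanyl)methyl. Going by the values given here, no measured pair carries this change, and the two values available are within the scatter of each other, so the data give no direction for the step. The author therefore expects the step of no change at the digits printed from compound 1 to compound 3 (within the scatter) to stay within the scatter. For compound 3 the estimated maximal response is 50%, with a range from 30% to 70%.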

Compound 3, largest response reached (reported as efficacy), in percent of the reference or control that the assay uses: 50%
Beside the measured number, compound 3's estimate shows no gap at the digits printed; the range from low to high includes it.
By their numbers in this assay, from the lowest: compounds 1, 3 and 2 (each within the scatter of the next).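

In this assay, going by these compounds alone, phenylsulfanyl in place of hydrogen on a saturated chain carbon bound to an aromatic carbon gives no change at the digits printed from compound 1 to compound 3 (within the scatter), the first step in this set that can be read at a single place. Compounds 1 and 2 differ in more than one place and so said nothing about this position alone; the step now shows that the maximal response stays within the scatter when the methyl of compound 1 becomes (phenylsulfanyl)methyl, a change that adds a six-membered aromatic ring of carbon only. Nothing measured here accounts for this result.

On these data alone, whether an amine, a carboxylic acid or a longer alkyl chain at the same place would also leave the response within the scatter remains open. As far as these compounds go, it is also open whether a phenoxy group would read like the phenylsulfanyl group, since this single step cannot separate the part played by the sulfur from that of the ring.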